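Hydroxy in place of chloro on compound 2

The source may hold more compounds than are shown below. What is called first, only, known or untested is meant among the compounds shown, and "the series" means these compounds.

Compound 1 `COc1cccc(/C=C2\CCC/C(=C\c3ccc(Cl)cc3Cl)C2=O)c1OC` is reported only as a limit of the assay (> 20000 nM) in a functional assay on A549 cells (Homo sapiens) for cytotoxicity, read by MTT assay, with a stated time of 72 h; on this read-out lower numbers stand for stronger inhibition and higher numbers for weaker inhibition. Within the data shown here, compound 2 `COc1ccc(/C=C2\CCC/C(=C\c3ccc(Cl)cc3)C2=O)cc1OC` gives the only actual number (10100 nM). Compound 3 `COc1ccc(/C=C2\CCC/C(=C\c3ccc(O)cc3)C2=O)cc1OC` carries hydroxy in place of the chloro of compound 2, on an aromatic carbon, para to a large group (hydroxy in place of chloro on an aromatic carbon). Among the measured compounds shown here, no measured single-place step is available for comparison. In this assay the expected change is small, leaning toward stronger inhibition and possibly not beyond the scatter (estimated a 1.4-fold lower number from compound 2 to compound 3 (0.16 log units; within the scatter)). Compound 3 is expected at about 7000 nM (estimated range 2500 nM to 20000 nM).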

Compound 3, half-maximal inhibitory concentration: > 20000 nM
Compound 3 gave a limit, no number; the forecaster's own chance of this, stated with the estimate: 15%; middle value at least 2.8-fold (0.45 log units) from the limit.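

In this assay, hydroxy in place of chloro on this aromatic carbon gives an at least 1.9-fold higher number from compound 2 to compound 3 (0.29 log units; that floor lies within the scatter). Among these compounds, this is the first reading at this position, and it shows no gain from 4-chlorophenyl to 4-hydroxyphenyl. The step is only a floor, since the value of compound 3 is a limit of the assay and not a number: the limit of > 20000 nM in this assay, at which 2 of the 3 values shown sit.

From the compounds shown here alone, how far compound 3 lies past that limit stays open. So does whether an amine or a carboxylic acid on the same aromatic carbon would give a measurable number in this assay.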